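Shifting the ring nitrogen in a bicyclic urea substituent

This account rests on a few compounds, and the source may have more. Where it says the series, first, only, none or still open, it means among the compounds named here.

Measured compounds in a physicochemical assay for solubility, read by HPLC, in phosphate buffer, measured as thermodynamic solubility, with a stated time of 24 h, at pH 7.4; on this read-out higher numbers stand for higher solubility and lower numbers for lower solubility:
compound 1, `C[C@@H]1CN([C@@H](C)CO)C(=O)c2cccc(NC(=O)Nc3cncc4ccccc34)c2O[C@H]1CN(C)S(=O)(=O)c1ccc2c(c1)OCCO2`, 84900 nM;
compound 2, `C[C@@H]1CN([C@@H](C)CO)C(=O)c2cccc(NC(=O)Nc3cccc4ncccc34)c2O[C@H]1CN(C)S(=O)(=O)c1ccc2c(c1)OCCO2`, 139000 nM;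
compound 3, `C[C@@H]1CN([C@@H](C)CO)C(=O)c2cccc(NC(=O)Nc3cccc4cccnc34)c2O[C@H]1CN(C)S(=O)(=O)c1ccc2c(c1)OCCO2`, 1800 nM.

Compound 2 gives the highest number of the three, though its step of a 1.6-fold higher number from compound 1 to compound 2 (0.21 log units; within the scatter) lies within the scatter, so compounds 1 and 2 are not separable on this assay. The step of a 77-fold lower number from compound 2 to compound 3 (1.89 log units; beyond the scatter) and the step of a 47-fold lower number from compound 1 to compound 3 (1.67 log units; beyond the scatter) are both large. Compound 4, `C[C@@H]1CN([C@@H](C)CO)C(=O)c2cccc(NC(=O)Nc3cccc4ccncc34)c2O[C@H]1CN(C)S(=O)(=O)c1ccc2c(c1)OCCO2`, differs from compound 2 by isoquinolin-8-yl in place of quinolin-5-yl on an amide-type nitrogen. Since isoquinolin-8-yl is a further isomer not yet seen, compound 3 shows the downside risk while compounds 1 and 2 show the likelier outcome. Compound 4 is therefore expected at 70000 nM, in a range from 12000 nM to 180000 nM, a step of a 2.0-fold lower number from compound 2 to compound 4 (0.30 log units; within the scatter).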

Compound 4, solubility: 101000 nM
Beside the measured number, compound 4's estimate is 1.4-fold (0.16 log units) below it; low and high end bracket the measured number.
By their numbers in this assay, from the lowest: compound 3; then compounds 1, 4 and 2 (each within the scatter of the next).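

In this assay, isoquinolin-8-yl on the amide-type nitrogen lands with the two high compounds: a 1.4-fold lower number from compound 2 to compound 4 (0.14 log units; within the scatter) and a 1.2-fold higher number from compound 1 to compound 4 (0.08 log units; within the scatter) both lie within the scatter. The large step, a 56-fold higher number from compound 3 to compound 4 (1.75 log units; beyond the scatter), shows that moving the ring nitrogen does not by itself bring a drop, since among these four isomers only quinolin-8-yl stands apart. No evidence is available on what lies behind this split. The compounds shown leave open how the number would respond to a non-isomeric substituent at this place, such as a bicyclic group carrying a dimethylamino group or a carboxylic acid.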